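A Chloro Substituent on an Ethoxy-Bearing Ring

The compounds below may be only part of what the source reports. "The series", "measured", "known", "first", "only" and "open" are said of these compounds alone.

Compound 1 `O=C(O)c1cnc(-c2ccccc2)[nH]c1=O`: 50 mg/kg
Compound 2 `CCOc1ccccc1-c1ncc(C(=O)O)c(=O)[nH]1`: 0.5 mg/kg
Compound 3 `O=C(O)c1cnc(-c2ccc(Cl)cc2)[nH]c1=O`: 5 mg/kg

Of the compounds shown here, three have been measured in a functional assay on the whole organism (strain Sprague-Dawley) for inhibition, with Rattus norvegicus as the target, with a stated time of 10 min (a higher number here means that more compound is needed for the effect, a lower number that less compound is needed), and all share the core of compound 1. Compound 2 differs from compound 1 by ethoxy in place of hydrogen on an aromatic carbon, and the step of a 100-fold lower number from compound 1 to compound 2 (2.00 log units; beyond the scatter) is large. Compound 3 differs from compound 1 by chloro in place of hydrogen on an aromatic carbon, and the step of a 10-fold lower number from compound 1 to compound 3 (1.00 log units; beyond the scatter) is modest. Compound 2 therefore gives the lowest number of the three, and both of its gaps to the other two lie beyond the scatter.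

Compound 4 `CCOc1ccc(Cl)cc1-c1ncc(C(=O)O)c(=O)[nH]1` has not yet been measured. It differs from compound 2 by chloro in place of hydrogen on an aromatic carbon. Going by the values given here, this is the same kind of change as the one from compound 1 to compound 3, but the surroundings are not identical: in compound 3 the chloro sits para to a large group, whereas in compound 4 it sits meta to a large group and para to an ethoxy group (3 heavy atoms). Because the earlier step of a 10-fold lower number from compound 1 to compound 3 (1.00 log units; beyond the scatter) lowered the number, a lowering is expected here as well, though its size is uncertain given the different place and given that compound 2 already sits at a low number. The step of a 2.5-fold lower number from compound 2 to compound 4 (0.40 log units; beyond the scatter) is expected to be smaller than the earlier one. Compound 4 is estimated at 0.2 mg/kg in this assay, with a likely range from 0.05 mg/kg to 1 mg/kg.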

Compound 4, dose for 50% inhibition: 0.5 mg/kg
Beside the measured number, compound 4's estimate is 2.5-fold (0.40 log units) below it; the measured number falls inside the stated range.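

In this assay, chloro in place of hydrogen on an aromatic carbon of the ethoxy-bearing ring gives no change at the digits printed from compound 2 to compound 4 (within the scatter), so adding this atom brings no measurable gain on this core. Going by these compounds alone, the same change therefore does not carry over with the same size from the core of compound 1 to the ethoxy-bearing core, as the two steps set side by side show: the same change on two cores in this assay, a 10-fold lower number (1.00 log units; beyond the scatter) from compound 1 to compound 3 and no change at the digits printed (within the scatter) from compound 2 to compound 4, 10-fold (1.00 log units) apart, beyond the scatter of two such steps This shows that a gain seen on one core cannot simply be assumed on another, but it does not show why the steps differ, since the chloro of compound 4 sits meta to a large group and para to an ethoxy group, a different place from the one it holds in compound 3, and a single pair of steps cannot separate the role of that place from the role of the ethoxy group.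

The compounds shown leave open whether chloro placed as in compound 3 would lower the number when the ethoxy group is present. They also leave open whether an amine in the place of this chloro, or a longer chain in the place of the ethoxy group, would move the number away from that of compound 2.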